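From Fluoro to Bromo: Expectation for Compound 4

The compounds below may be only part of what the source reports. "The series", "measured", "known", "first", "only" and "open" are said of these compounds alone.

In a functional assay on MDA-MB-231 cells (Homo sapiens) for inhibition (on this read-out higher numbers stand for weaker inhibition and lower numbers for stronger inhibition), compound 2 `O=C(/C=C/c1ccc(F)c(F)c1)c1ccc(B(O)O)cc1` gives 8800 nM and stands alongside compound 1 `O=C(/C=C/c1ccc(F)c(Cl)c1)c1ccc(B(O)O)cc1`, which gives 8500 nM, and compound 3 `O=C(/C=C/c1ccc(B(O)O)cc1)c1ccc(Cl)c(Cl)c1`, which gives 8000 nM, all three within the scatter of one another. Compound 4 `O=C(/C=C/c1ccc(F)c(Br)c1)c1ccc(B(O)O)cc1` differs from compound 2 by bromo in place of fluoro on an aromatic carbon. Going by the values given here, only one measured step bears on this change, the exchange of one halogen for another at the same aromatic carbon, and there a 1.0-fold higher number from compound 1 to compound 2 (0.02 log units; within the scatter). Compound 4 is therefore expected to show a 1.0-fold lower number from compound 2 to compound 4 (0.02 log units; within the scatter) in this assay, no step beyond the scatter, because a 1.0-fold higher number from compound 1 to compound 2 (0.02 log units; within the scatter). Compound 4 is estimated at 8500 nM, with a range from 4000 nM to 18000 nM.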

Compound 4, half-maximal inhibitory concentration: 9500 nM
Compound 4: the middle estimate sits 1.1-fold (0.05 log units) below what was measured; measured number inside the range.
By their numbers in this assay, from the lowest: compounds 3, 1, 2 and 4 (each within the scatter of the next).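

In this assay, bromo joins fluoro and chloro at this aromatic carbon, ortho to a fluoro group, and the read-out stays within the scatter for both exchanges: a 1.1-fold higher number from compound 2 to compound 4 (0.03 log units; within the scatter), and a 1.1-fold higher number from compound 1 to compound 4 (0.05 log units; within the scatter). The earlier compounds shown here showed only the exchange of chloro for fluoro here, whereas all three halogens now read alike at this position. Nothing measured here offers an explanation for this. On these data alone, it remains open whether an amine, a carboxylic acid or a longer chain at this carbon would shift the number beyond the scatter.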